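This account rests on a few compounds, and the source may have more. Where it says the series, first, only, none or still open, it means among the compounds named here.

Three compounds on a shared core have numbers in an ADME assay on microsomes from liver (Rattus norvegicus) for metabolic stability; a lower number here means that the compound disappears faster, a higher number that the compound lasts longer. Compound 1 `COc1cc2c(Oc3ccc(Nc4nccc5[nH]cc(-c6ccc(F)cc6)c(=O)c45)cc3F)ccnc2cc1OCCO` gives 1.48 h, compound 2 `O=c1c(-c2ccc(F)cc2)c[nH]c2ccnc(Nc3ccc(Oc4ccnc5cc(OCCO)ccc45)c(F)c3)c12` gives 1.51 h and compound 3 `O=c1c(-c2ccc(F)cc2)c[nH]c2ccnc(Nc3ccc(Oc4ccnc5cc(O)ccc45)c(F)c3)c12` gives 0.893 h, so compound 3 stands within the usual scatter of both others. Compound 4 `COCCOc1ccc2c(Oc3ccc(Nc4nccc5[nH]cc(-c6ccc(F)cc6)c(=O)c45)cc3F)ccnc2c1` differs from compound 3 by 2-methoxyethyl in place of hydrogen on an oxygen on an aromatic ring, which turns hydroxy into 2-methoxyethoxy. The closest measured change is a 1.7-fold lower number from compound 2 to compound 3 (0.23 log units; within the scatter), where hydrogen replaces 2-hydroxyethyl on an oxygen on an aromatic ring, and it stays within the scatter. The other measured change, a 1.0-fold higher number from compound 1 to compound 2 (0.01 log units; within the scatter), concerns a methoxy on an aromatic carbon and also stays within the scatter, so it offers only indirect support. Compound 4 carries a chain on that oxygen, as compound 2 does, so a small move towards a higher number in this assay is expected, but nothing beyond the scatter. The expected change is a 1.5-fold higher number from compound 3 to compound 4 (0.16 log units; within the scatter). For compound 4 the estimated half-life is 1.3 h, with an expected range of 0.7 h to 2.4 h.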

Compound 4, half-life: 1.73 h
Estimate against measurement, compound 4: 1.3-fold (0.12 log units) below, within the range that was stated.
By their numbers in this assay, from the lowest: compounds 3, 1, 2 and 4 (each within the scatter of the next).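

In this assay, putting 2-methoxyethyl on the oxygen of the aromatic ring gives a 1.9-fold higher number from compound 3 to compound 4 (0.29 log units; within the scatter), so this ether chain, like the 2-hydroxyethyl chain of compound 2, leaves the half-life within the scatter of the free hydroxy compound. The new comparison is at the end of the chain: methyl in place of hydrogen on its oxygen gives a 1.1-fold higher number from compound 2 to compound 4 (0.06 log units; within the scatter), so in this pair the terminal hydroxy and its methyl ether cannot be told apart in this assay. Nothing available here bears on why these numbers fall as they do.

All the substituents shown on this oxygen remain within the scatter of one another where a step is printed. As far as these compounds go, whether an amine, a carboxylic acid or a longer chain at this position would give a step beyond the scatter stays open.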